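Furylvinyl series: dimethylamino for fluoro on the aryl ring

The source may report more compounds than this note shows. Statements on the series, on what has been measured and on what is new or still open speak of the compounds shown alone.

Going by the values given here, compound 2 `Fc1ccc(-c2nnc3sc(/C=C/c4ccco4)nn23)cc1` stands lowest of the three numbers so far in an assay for inhibition of histone-lysine N-methyltransferase, H3 lysine-79 specific (Homo sapiens), read by scintillation counting, with stated times of 15 min and 60 min, tested at 50 uM, in the presence of a further agent that is not named here (on this read-out higher numbers stand for a stronger effect at the one concentration tested and lower numbers for a weaker effect), with compound 2 giving 44%. Compound 1 `C(=C/c1nn2c(-c3ccncc3)nnc2s1)\c1ccco1` gives 67% in this assay, and compound 3 `Cc1cccc(-c2nnc3sc(/C=C/c4ccco4)nn23)c1` gives 69%; the two lie within the scatter of each other, so no order between them is claimed. The measured steps differ only at the aryl group on the shared core: a number 23 percentage points lower from compound 1 to compound 2 (beyond the scatter), and a number 25 percentage points higher from compound 2 to compound 3 (beyond the scatter). Both steps are modest and both show the fluoro-bearing compound 2 at the low end.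

Compound 4 `CN(C)c1ccc(-c2nnc3sc(/C=C/c4ccco4)nn23)cc1` differs from compound 2 in one place: dimethylamino in place of fluoro on an aromatic carbon. Among the compounds with values here, no measured step exchanges fluoro for dimethylamino, so the bearing steps are only indirect: both replacements at this aryl position moved away from compound 2 by a modest amount, upward. On that basis a modest step upward is expected in this assay, though a result within the scatter cannot be ruled out. Compound 4 is therefore estimated at 55%, within a range of 30% to 80%, which means an expected step of a number 11 percentage points higher from compound 2 to compound 4 (beyond the scatter).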

Compound 4, a percentage reported as inhibition, at one concentration (the size of the read-out at that concentration, not a potency): 60%
Estimate against measurement, compound 4: 5 percentage points below, within the range that was stated.
By their numbers in this assay, from the lowest: compound 2; then compounds 4, 1 and 3 (each within the scatter of the next).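

In this assay, going by these compounds alone, the exchange of fluoro for dimethylamino on the aromatic carbon para to a large group gives a number 16 percentage points higher from compound 2 to compound 4 (beyond the scatter), a change made at the substituent itself, whereas the earlier steps exchanged whole aryl groups. Compound 2 now stands apart from three different aryl groups, while compounds 4, 1 and 3 form a run in which each lies within the scatter of the next, and none of the compounds shown goes against this low position of the fluoro-bearing compound 2. No measurement at hand bears on the origin of this step.

The compounds shown leave open whether fluoro itself lowers the number or dimethylamino raises it, since a plain unsubstituted phenyl at this position would be needed to separate the two, and a methoxy group, a chlorine atom or a carboxylic acid at the same place would show how far the range of substituents extends. From the compounds shown here alone, all of these numbers are single-concentration read-outs rather than potencies, so the size of the differences between the compounds at other concentrations also remains open.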